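Thioester variant of the isopropyl dienoate: lipophilicity notes

A few compounds are considered here, and "the series" means these few. Any claim that something is new, unique, unknown or untested is made for them only; others in the source may bear on it.

Measured so far:
- compound 1, `CC(/C=C/CC(C)CCCC(C)C)=C\C(=O)OC(C)C`: 7.15
- compound 2, `COC(CCC(C)C/C=C/C(C)=C/C(=O)OC(C)C)C(C)C`: 5.95

In a physicochemical assay for lipophilicity (a higher number here means a more lipophilic compound, a lower number a more polar compound), compound 1 stands highest of the two numbers; its nearest neighbour is compound 2, reached by a number 1.20 log units lower from compound 1 to compound 2 (beyond the scatter). That step rests on a methoxy in place of hydrogen on a saturated chain carbon bound to two saturated chain carbons, and it does not touch the ester end of the core of compound 1.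

Compound 3, `CCSC(=O)/C=C(C)/C=C/CC(C)CCCC(C)C`, is not yet measured. It differs from compound 1 as follows: ethylsulfanyl in place of isopropoxy on a carbonyl carbon. Going by the values given here, no measured step changes the carbonyl substituent, so nothing here bears directly on this change. On the shared core, with one carbon fewer and sulfur in place of oxygen, a step of no more than the usual scatter is expected, a number 0.05 log units higher from compound 1 to compound 3 (within the scatter). Compound 3 is therefore estimated at 7.2, with a range from 6.6 to 7.8.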

Compound 3, partition coefficient: 7.98
For compound 3 the middle estimate is 0.78 log units below the measured one; measured number outside the range, above it.
By their numbers in this assay, from the lowest: compound 2; then compound 1; then compound 3.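

In this assay, the carbonyl substituent proves to be a position where the number moves: ethylsulfanyl in place of isopropoxy on a carbonyl carbon gives a clear upward step (a number 0.83 log units higher from compound 1 to compound 3 (beyond the scatter)). Going by these compounds alone, this is the first measured change at this end of the shared core, and it runs opposite in sign to the only earlier step, the methoxy change on the saturated chain (a number 1.20 log units lower from compound 1 to compound 2 (beyond the scatter)). Nothing available on these compounds accounts for the size or direction of the new step.

The step exchanges both the heteroatom and the carbon group at once, so the compounds shown do not separate the two; ethoxy and isopropylsulfanyl on the same carbonyl carbon would divide them. Going by these compounds, whether the methoxy step keeps its size with ethylsulfanyl on the carbonyl also stays open.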